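Chalcone series: trifluoromethyl for methyl on a second core

A few compounds are considered here, and "the series" means these few. Any claim that something is new, unique, unknown or untested is made for them only; others in the source may bear on it.

Measured compounds in an assay on isolated protein for inhibition of Amine oxidase [flavin-containing] B (Homo sapiens); on this read-out lower numbers stand for stronger inhibition and higher numbers for weaker inhibition:
compound 1 `CCOc1ccc(C(=O)/C=C/c2ccc(C)cc2)cc1`, 210 nM
compound 2 `CCOc1ccc(C(=O)/C=C/c2ccc(C(F)(F)F)cc2)cc1`, 210 nM
compound 3 `Cc1ccc(/C=C/C(=O)c2ccc(-n3ccnc3)cc2)cc1`, 320 nM

Compound 1 and compound 2 differ by trifluoromethyl in place of methyl on an aromatic carbon, and that step gave no change at the digits printed from compound 1 to compound 2 (within the scatter). Compound 3 carries a different core: its difference from compound 1 is 1H-imidazol-1-yl in place of ethoxy on an aromatic carbon, and the step reads a 1.5-fold higher number from compound 1 to compound 3 (0.18 log units; within the scatter). Compound 4 `O=C(/C=C/c1ccc(C(F)(F)F)cc1)c1ccc(-n2ccnc2)cc1` has not been measured; it stands to compound 3 as compound 2 stands to compound 1, the change being (trifluoromethyl in place of methyl on an aromatic carbon), the same change as before. Since that change on the core of compound 1 produced no change at the digits printed from compound 1 to compound 2 (within the scatter), the step from compound 3 to compound 4 is expected to be no change at the digits printed from compound 3 to compound 4 (within the scatter), resting on that single earlier example and on compound 3 giving 320 nM. Compound 4 is therefore estimated at 320 nM in this assay, with a range of 150 nM to 680 nM.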

Compound 4, half-maximal inhibitory concentration: > 10000 nM
Compound 4 was reported as a limit; the forecaster's own chance of this, stated with the estimate: 3%; middle value at least 31-fold (1.49 log units) away from the limit.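

In this assay compound 4 gives > 10000 nM, which is a limit of the assay and not a number. Neither single change carries from one core to the other, the steps reading an at least 31-fold higher number from compound 3 to compound 4 (1.49 log units; beyond the scatter) and an at least 47-fold higher number from compound 2 to compound 4 (1.67 log units; beyond the scatter): the same change on two cores in this assay, no change at the digits printed (within the scatter) from compound 1 to compound 2 and an at least 31-fold higher number (1.49 log units; beyond the scatter) from compound 3 to compound 4, at least 31-fold (1.49 log units) apart, beyond the scatter of two such steps The limit leaves the true size of both steps unknown, and the data show neither why the pairing fails nor how the change would behave on any further core.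

As far as these compounds go, it remains open whether the loss is particular to trifluoromethyl combined with 1H-imidazol-1-yl. Chlorine or methoxy in place of the methyl, or an amine or a carboxylic acid in place of 1H-imidazol-1-yl, would be needed to narrow this down.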